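The compounds below may be only part of what the source reports. "The series", "measured", "known", "first", "only" and "open" are said of these compounds alone.

In an ADME assay on Vero cells (Chlorocebus sabaeus) for cytotoxicity, read by MTT assay, with a stated time of 72 h (a lower number here means that less compound is needed, a higher number that more compound is needed for the effect), compound 2 (`O=C(Nc1nc(-c2ccccn2)cs1)c1ccc(OCc2ccccc2)cc1`) gives 2300 nM and lies within the scatter of compound 3 (`COc1cccc(C(=O)Nc2nc(-c3ccccn3)cs2)c1`) at 2800 nM while compound 1 (`O=C(Nc1nc(-c2ccccn2)cs1)c1cccc(OCc2ccccc2)c1`) stands apart at 14400 nM in this small set. Compound 4 (`COc1ccc(C(=O)Nc2nc(-c3ccccn3)cs2)cc1`) differs from compound 2 by hydrogen in place of phenyl on a saturated chain carbon bound to an oxygen on an aromatic ring in a change of benzyloxy to methoxy. Among the measured compounds shown here, the one measured step of this kind is a 5.1-fold lower number from compound 1 to compound 3 (0.71 log units; beyond the scatter) and it starts from the highest number of the set. Compound 2 already stands close to compound 3 at 2800 nM so only a small part of that step is expected here. The expected step, in the same direction, is a 1.5-fold lower number from compound 2 to compound 4 (0.19 log units; within the scatter) and no more than that. For compound 4 the estimated value is 1500 nM with 500 nM and 5000 nM as the ends of the expected range.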

Compound 4, half-maximal effective concentration: 9200 nM
Compound 4: the middle estimate sits 6.1-fold (0.79 log units) below what was measured, and the stated range ends below it.
By their numbers in this assay, from the lowest: compounds 2 and 3 (each within the scatter of the next); then compounds 4 and 1 (each within the scatter of the next).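

In this assay, the change from benzyloxy to methoxy has no fixed direction: on the core of compound 2 it raises the number (a 4.0-fold higher number from compound 2 to compound 4 (0.60 log units; beyond the scatter)), while on the core of compound 1 it lowers it (a 5.1-fold lower number from compound 1 to compound 3 (0.71 log units; beyond the scatter)). The outcome of this change therefore depends on the core that carries it, and a step read on one core does not carry over to the other: the same change on two cores in this assay, a 5.1-fold lower number (0.71 log units; beyond the scatter) from compound 1 to compound 3 and a 4.0-fold higher number (0.60 log units; beyond the scatter) from compound 2 to compound 4, 21-fold (1.31 log units) apart, beyond the scatter of two such steps.

Going by these compounds, whether a longer chain, such as propoxy, follows compound 2 or compound 1 remains open. Also open, on these data alone, is how an amine at this place would compare with the methoxy of compound 3 and compound 4.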